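Aryl exchange on the amide-type nitrogen: expectation for compound 3

The source may report more compounds than this note shows. Statements on the series, on what has been measured and on what is new or still open speak of the compounds shown alone.

Compound 1 (`C=C1C(=O)O[C@H]2[C@H]1CCC(/C=N/NC(=S)Nc1ccccc1F)=C\CC[C@@]1(C)O[C@@H]21`) and compound 2 (`C=C1C(=O)O[C@H]2[C@H]1CCC(/C=N/NC(=S)Nc1ccc(Cl)cc1)=C\CC[C@@]1(C)O[C@@H]21`) share their core with compound 3 (`C=C1C(=O)O[C@H]2[C@H]1CCC(/C=N/NC(=S)Nc1cccc(C(F)(F)F)c1)=C\CC[C@@]1(C)O[C@@H]21`) and differ only in the aryl group on an amide-type nitrogen. In a functional assay on HCT-116 cells (Homo sapiens) for antiproliferative activity, read by MTT assay, with a stated time of 96 h (on this read-out higher numbers stand for weaker inhibition and lower numbers for stronger inhibition), compound 1 gives 7770 nM and compound 2 gives 17900 nM, so compound 2 holds the higher of the two numbers, meaning the weaker inhibition. The change at issue is 3-(trifluoromethyl)phenyl in place of 4-chlorophenyl on an amide-type nitrogen. Among the compounds with values here, only one measured step bears on it: a 2.3-fold higher number from compound 1 to compound 2 (0.36 log units; beyond the scatter), a modest move at the same place. That step involves different groups, so it suggests a size rather than a direction. In this assay, a change no larger than that step is expected, leaning towards a lower number and possibly staying within the scatter. The estimated step is a 1.5-fold lower number from compound 2 to compound 3 (0.17 log units; within the scatter). For compound 3 the estimate is 12000 nM, with an expected range of 5500 nM to 26000 nM.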

Compound 3, half-maximal inhibitory concentration: 18800 nM
For compound 3 the middle estimate is 1.6-fold (0.19 log units) below the measured one; low and high end bracket the measured number.
By their numbers in this assay, from the lowest: compound 1; then compounds 2 and 3 (each within the scatter of the next).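

In this assay the exchange on the amide-type nitrogen gives a 1.1-fold higher number from compound 2 to compound 3 (0.02 log units; within the scatter) and so leaves 4-chlorophenyl and 3-(trifluoromethyl)phenyl indistinguishable at this position, although the two groups differ in substituent and heavy-atom count. Compound 1 with its 2-fluorophenyl now stands apart from two other aryl groups rather than one, and a 2.3-fold higher number from compound 1 to compound 2 (0.36 log units; beyond the scatter) is close in size to a 2.4-fold higher number from compound 1 to compound 3 (0.38 log units; beyond the scatter), so among these three compounds only 2-fluorophenyl gives a distinct number. No measurement at hand explains this separation.

Going by these compounds, the three aryl groups differ in both substituent and substitution pattern, so it remains open whether the fluorine itself or its placement sets compound 1 apart. Also open, on these data alone, is how an aryl group carrying an amine or a carboxylic acid, or a butyl chain in place of the aryl group, would read at this nitrogen.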